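The source may report more compounds than this note shows. Statements on the series, on what has been measured and on what is new or still open speak of the compounds shown alone.

Compound 1 `CN1CCN=C(N(C#N)Cc2ccc(Cl)nc2)C1=O`: > 10000 nM
Compound 2 `NC(=S)N/N=C1/NCCN(Cc2ccc(Cl)nc2)C1=O`: 3920 nM
Compound 3 `CN1C/C(=N\C#N)N(Cc2ccc(Cl)nc2)CC1=O`: > 10000 nM

In an assay on membranes from Head for displacement of a labelled ligand from Nicotinic acetylcholine receptor alpha 5 subunit (Musca domestica), read by scintillation counting, with a stated time of 1 h (a lower number here means a stronger inhibitor, a higher number a weaker inhibitor), compound 1 gives only a limit, > 10000 nM. Compound 3 likewise gives only a limit, > 10000 nM. Going by the values given here, compound 2 stands alone as the one compound with a real number here, at 3920 nM, since the other two values sit at the limit of > 10000 nM in this assay, at which 2 of the 3 values shown sit. Compound 4 `O=C1/C(=N\S(=O)(=O)C(F)(F)F)NCCN1Cc1ccc(Cl)nc1` has not been measured. It differs from compound 2 by a group of 7 heavy atoms (1 carbon, 2 oxygen, 3 fluorine, 1 sulfur; no ring) in place of a group of 4 heavy atoms (1 carbon, 2 nitrogen, 1 sulfur; no ring), on a double-bonded nitrogen. Among the compounds with values here, no step between measured compounds is available to size this change, so any expectation rests on compound 2 alone. Compound 4 is expected to land near compound 2, with a step of a 1.3-fold lower number from compound 2 to compound 4 (0.12 log units; within the scatter), and its estimated value is 3000 nM within 500 nM to 20000 nM.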

Compound 4, inhibition constant: 593 nM
Compound 4: the middle estimate sits 5.1-fold (0.70 log units) above what was measured, and the stated range covers the measured number.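

Placing (trifluoromethyl)sulfonyl on the double-bonded nitrogen gives a 6.6-fold lower number from compound 2 to compound 4 (0.82 log units; beyond the scatter) in this assay. This single step shows that the group on this nitrogen can be exchanged without losing binding, and that the exchange can give a stronger inhibitor. The earlier compounds could not show this, since only one of them gave a real number: the limit of > 10000 nM in this assay, at which 2 of the 4 values shown sit.

One step cannot say what in the new group matters. Going by these compounds, how methylsulfonyl, acetyl or a plain amine on this nitrogen would compare remains open.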